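Removing the Side Chain from Compound 1

The compounds below may be only part of what the source reports. "The series", "measured", "known", "first", "only" and "open" are said of these compounds alone.

Within the data shown here, compound 1 `COc1ccc(N(C)c2nc(C)nc3ccccc23)cc1C(=O)OCCC[Se]C#N` stands at the top of the three numbers known in a functional assay on LoVo cells (Homo sapiens) for inhibition, read by MTT assay, with a stated time of 48 h (a higher number here means a weaker inhibitor, a lower number a stronger inhibitor), where compound 1 gives 854 nM. Its nearest neighbour is compound 2 `COc1ccc(N(C)c2nc(C)nc3ccccc23)cc1C(=O)OCCCCC[Se]C#N`, which in this assay gives 714 nM, and the gap is a 1.2-fold lower number from compound 1 to compound 2 (0.08 log units; within the scatter). Far below both lies compound 3 `C[Se]c1ccc(N(C)c2nc(C3CC3)nc3ccccc23)cc1`, which in this assay gives 11 nM.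

Compound 4 `COc1ccc(N(C)c2nc(C)nc3ccccc23)cc1` is compound 1 stripped of its side chain: a hydrogen atom in place of a group of 9 heavy atoms (5 carbon, 1 nitrogen, 2 oxygen, 1 selenium; no ring), on an aromatic carbon. Among the measured compounds shown here, the one measured step that touches that chain, a lengthening of it, is a 1.2-fold lower number from compound 1 to compound 2 (0.08 log units; within the scatter), so the chain's length is not what sets the number. For the measured compounds named here, compound 3, which carries no such chain at all but also differs from compound 1 in two further places, shows a far lower number than compound 1; no single step connects the pair. On that basis compound 4 is expected to land well below compound 1, with an expected step of a 28-fold lower number from compound 1 to compound 4 (1.45 log units; beyond the scatter), though the added differences in compound 3 leave the size uncertain. Compound 4 is estimated at 30 nM, within 5 nM to 200 nM.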

Compound 4, half-maximal inhibitory concentration: 8 nM
Beside the measured number, compound 4's estimate is 3.8-fold (0.57 log units) above it; measured number inside the range.
By their numbers in this assay, from the lowest: compounds 4 and 3 (each within the scatter of the next); then compounds 2 and 1 (each within the scatter of the next).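

In this assay, removing the whole side chain from the aromatic carbon ortho to the methoxy group gives a 110-fold lower number from compound 1 to compound 4 (2.03 log units; beyond the scatter), a large step. The earlier lengthening of the chain had shown only that its length made no difference beyond the scatter; this step shows that having the chain at this position, rather than a hydrogen atom, separates a high number from a low one. No measurement shown here accounts for the size of this step.

Which part of the chain carries the step remains open, since the carbonyl, the saturated carbons, the selenium and the nitrile all leave together. Also open, as far as these compounds go, is whether a smaller group at this position, such as a carboxylic acid or an amine, would stay close to compound 4 or move towards compound 1.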